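Bromo in Place of Nitro: An Expected Small Step

The source may hold more compounds than are shown below. What is called first, only, known or untested is meant among the compounds shown, and "the series" means these compounds.

Of the compounds shown here, two have been measured in a functional assay on the whole organism (strain Wistar) with Rattus norvegicus as the target, with a stated time of 15 days, at a dose of 100 mg/kg by the oral route (a lower number here means a weaker effect, a higher number a stronger effect of the compound at the dose given), so far. Compound 1 `O=C1NC(=O)/C(=C/c2ccc(OCc3csc(-c4ccccc4)n3)cc2)S1` gives 54% in this assay. Compound 2 `O=C1NC(=O)/C(=C/c2ccc(OCCSc3nnc(-c4ccc([N+](=O)[O-])cc4)[nH]3)cc2)S1` gives 22.1% in this assay, the lower of the two numbers, and the gap to compound 1 lies beyond the usual scatter of such measurements. Going by the values given here, no pair of measured compounds differing in a single place is available, so no measured step guides what a single change at the aromatic ring is worth.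

Compound 3 `O=C1NC(=O)/C(=C/c2ccc(OCCSc3nnc(-c4ccc(Br)cc4)[nH]3)cc2)S1` has not yet been measured. It differs from compound 2 in one place: bromo in place of nitro on an aromatic carbon. Nothing in the two measured values speaks to the size of this particular change, so the expectation rests on compound 2 alone. The step from compound 2 to compound 3 is expected to be small and within the scatter, in either direction, a number 2.9 percentage points higher from compound 2 to compound 3 (within the scatter). Compound 3 is therefore estimated to give 25% in this assay, between 10% and 45%.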

Compound 3, a percentage reported as activity, at one dose (the size of the read-out at that dose, not a potency): 45.7%
The estimate for compound 3 lay 20.7 percentage points below the measured number; the whole stated range lies below it.
By their numbers in this assay, from the lowest: compound 2; then compounds 3 and 1 (each within the scatter of the next).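

In this assay, the change from 4-nitrophenyl to 4-bromophenyl comes with a number 23.6 percentage points higher from compound 2 to compound 3 (beyond the scatter) on the same shared core. Going by these compounds alone, this is the first measured step at a single place, and it shows that the read-out at the dose given responds to the group on this aromatic carbon, para to a large group, rather than staying unchanged across this swap. The change removes a nitro group with 3 heavy atoms and 2 hydrogen-bond acceptors and introduces a bromo group with 1 heavy atom and no hydrogen-bond acceptor, but no measurement among these compounds indicates which of these differences, if any, accounts for the step.

The compounds shown leave open whether this gain is particular to bromo or would also appear with chloro, methoxy or an amine on the same carbon, or with no substituent there at all. They also leave open whether the same swap would give a step of similar size with a longer chain in place of the one that joins the shared core to the phenyl-bearing ring.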